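The source may report more compounds than this note shows. Statements on the series, on what has been measured and on what is new or still open speak of the compounds shown alone.

In a functional assay (aorta) for inhibition, with Rattus norvegicus as the target (a higher number here means a weaker inhibitor, a lower number a stronger inhibitor), compound 1 `C/N=C(\S)[C@]1(c2cccc(F)c2)CCCC[S+]1[O-]` gives 7000 nM and compound 2 `C/N=C(\S)[C@]1(c2ccc(-c3ccccc3)cc2)CCCC[S+]1[O-]` gives 12000 nM, two values within the usual scatter of each other. Compound 3 `N#C[C@]1(c2cccnc2)CCCC[S+]1[O-]` stands at > 30000 nM, which is a limit of the assay and not a number. Compound 4 `C/N=C(\SC)[C@]1(c2cccnc2)CCCC[S+]1[O-]` carries, on a saturated ring carbon, a group of 5 heavy atoms in place of the cyano of compound 3 (a group of 5 heavy atoms (3 carbon, 1 nitrogen, 1 sulfur; no ring) in place of a group of 2 heavy atoms (1 carbon, 1 nitrogen; no ring), on a saturated ring carbon). The entering group resembles the sulfur-and-nitrogen group of compound 1 at 7000 nM, so a modest step towards stronger inhibition is expected in this assay. The estimated step is an at least 2.1-fold lower number from compound 3 to compound 4 (0.33 log units; beyond the scatter). For compound 4 the estimated value is 14000 nM, with an expected range of 4000 nM to 30000 nM.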

Compound 4, concentration for 90% inhibition: > 30000 nM
Compound 4 ended at the assay's limit; the forecaster's own chance of this, stated with the estimate: 35%; at least 2.1-fold (0.33 log units) between middle value and limit.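

Compound 3 and compound 4 both end at a limit of this assay, not at a number, so no step between them can be read: the limit of > 30000 nM in this assay, at which 2 of the 4 values shown sit.

From the compounds shown here alone, whether the group replacing the cyano strengthens or weakens inhibition in this assay stays open.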